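The source may hold more compounds than are shown below. What is called first, only, known or untested is meant among the compounds shown, and "the series" means these compounds.

Measured compounds:
compound 1 `COC(=O)C1=C(C)N=C(C)/C(=C(/O)OC)C1c1cccc(N/C(=N/CCNC2CCN(c3ccccc3OC(F)(F)F)CC2)NC#N)c1` with 28 nM
compound 2 `COC(=O)C1=C(C)N=C(C)/C(=C(/O)OC)C1c1cccc(NC(=O)NCCNC2CCN(c3ccccc3C)CC2)c1` with 4 nM

In an assay on SK-N-MC cells for inhibition of Neuropeptide Y receptor type 1 (Homo sapiens) (on this read-out lower numbers stand for stronger inhibition and higher numbers for weaker inhibition), compound 2 gives 4 nM, the lower of the two numbers shown. Its nearest neighbour, compound 1, gives 28 nM in this assay, a gap beyond the usual scatter; the two structures differ in more than one place, so the values are simply set side by side here. Compound 3 `COC(=O)C1=C(C)N=C(C)/C(=C(/O)OC)C1c1cccc(NC(=O)NCCNC2CCN(c3cccc(Cl)c3)CC2)c1` has not yet been measured. It differs from compound 2 by 3-chlorophenyl in place of 2-methylphenyl on an amine nitrogen in a ring. Among the compounds with values here, no measured pair shows this exchange, so the size of the step is open. The expectation for compound 3 in this assay is a small move towards a higher number, close to or only just beyond the scatter, which corresponds to the step of a 1.8-fold higher number from compound 2 to compound 3 (0.24 log units; within the scatter). Compound 3 is therefore estimated at 7 nM, with a range from 2 nM to 25 nM.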

Compound 3, half-maximal inhibitory concentration: 8 nM
The estimate for compound 3 lay 1.1-fold (0.06 log units) below the measured number, and the stated range covers the measured number.
By their numbers in this assay, from the lowest: compounds 2 and 3 (each within the scatter of the next); then compound 1.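

In this assay, within the data shown here, exchanging 2-methylphenyl for 3-chlorophenyl on the amine nitrogen in a ring is a step of a 2.0-fold higher number from compound 2 to compound 3 (0.30 log units; within the scatter), the first comparison here between compounds that differ in one place. At this position, then, the two groups, which have the same count of heavy atoms, are not told apart by this read-out, even though both the substituent and its place on the phenyl differ. Nothing available here bears on the reason for this outcome.

Because the substituent and its place change together in this single step, the compounds shown do not separate the contribution of either one. Also open, from the compounds shown here alone, is how this position responds to a group such as a methoxy, a carboxylic acid or a pyridine ring in place of the substituted phenyl.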